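Maximal response across side-chain variants of a shared core

A few compounds are considered here, and "the series" means these few. Any claim that something is new, unique, unknown or untested is made for them only; others in the source may bear on it.

Three analogues on one core have been measured in a functional assay on CHO cells for agonist activity at Alpha-1A adrenergic receptor (Homo sapiens), read by fluorescence and calcium flux; a lower number here means a smaller maximal response, a higher number a larger maximal response. Compound 1 `CCOCc1cccc2c1CCC2c1ncc[nH]1` gives 64%, compound 2 `COCCc1cccc2c1CCC2c1ncc[nH]1` gives 50%, and compound 3 `c1cc(Cn2ccnn2)c2c(c1)C(c1ncc[nH]1)CC2` gives 62%. Every step among them sits on a saturated chain carbon bound to an aromatic carbon: a number 14 percentage points lower from compound 1 to compound 2 (beyond the scatter), a number 2 percentage points lower from compound 1 to compound 3 (within the scatter), and a number 12 percentage points higher from compound 2 to compound 3 (beyond the scatter). Compound 3 thus stands second highest of the three, within the scatter of compound 1 and modestly above compound 2.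

Compound 4 `Fc1ccn(Cc2cccc3c2CCC3c2ncc[nH]2)n1` differs from compound 3 in one place: 3-fluoro-1H-pyrazol-1-yl in place of 1H-1,2,3-triazol-1-yl on a saturated chain carbon bound to an aromatic carbon. Among the measured compounds shown here, the steps that bear on this are those leading into compound 3, a number 2 percentage points lower from compound 1 to compound 3 (within the scatter) and a number 12 percentage points higher from compound 2 to compound 3 (beyond the scatter), which show that swaps at this place have so far moved the maximal response only modestly or not at all beyond the scatter. Since compound 4 keeps one five-membered aromatic ring at the same place, the expected step of a number 4 percentage points lower from compound 3 to compound 4 (within the scatter) is none beyond the scatter. Compound 4 is therefore estimated at 58% in this assay, with a range from 44% to 72%.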

Compound 4, largest response reached (Emax), in percent of the reference or control that the assay uses: 83%
Beside the measured number, compound 4's estimate is 25 percentage points below it; the measured number lies above the stated range.
By their numbers in this assay, from the lowest: compound 2; then compounds 3 and 1 (each within the scatter of the next); then compound 4.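

In this assay the step of a number 21 percentage points higher from compound 3 to compound 4 (beyond the scatter) shows that exchanging one five-membered aromatic ring for another on this saturated chain carbon bound to an aromatic carbon can move the maximal response beyond the scatter, so keeping a ring of that size does not by itself hold the response level. Among the compounds shown here, the 3-fluoro-1H-pyrazol-1-yl group also stands clear of the ethoxy and methoxymethyl groups, with a number 19 percentage points higher from compound 1 to compound 4 (beyond the scatter) and a number 33 percentage points higher from compound 2 to compound 4 (beyond the scatter) in this series, the last being the only large step here so far. Nothing available accounts for the rise.

On these data alone, the step to compound 4 changes the ring and adds fluorine together, so the share of each remains open, and the plain 1H-pyrazol-1-yl group would separate them. As far as these compounds go, how an amine or a carboxylic acid would behave at this place also remains open.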